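This account rests on a few compounds, and the source may have more. Where it says the series, first, only, none or still open, it means among the compounds named here.

Compound 1 `NC(=O)c1ncn2c(=O)n(Cc3ccccc3)nnc12` — > 50000 nM
Compound 2 `COc1ccc(Cn2nnc3c(C(N)=O)ncn3c2=O)cc1` — > 50000 nM

In a functional assay on SNB-19 cells (Homo sapiens) for inhibition, read by MTT assay, with a stated time of 7 days (on this read-out higher numbers stand for weaker inhibition of growth and lower numbers for stronger inhibition of growth), compound 1 gives > 50000 nM, which is a limit of the assay rather than a measured number. Compound 2 gives > 50000 nM in this assay, again only a limit. Going by the values given here, the one measured step, a step that the two limits leave unreadable from compound 1 to compound 2, therefore tells nothing about size or direction, since (the limit of > 50000 nM in this assay, at which 2 of the 2 values shown sit). Compound 3 `NC(=O)c1ncn2c(=O)n(C(c3ccccc3)c3ccccc3)nnc12` differs from compound 1 by phenyl in place of hydrogen on a saturated chain carbon bound to an aromatic carbon and an aromatic nitrogen. Among the compounds with values here, no measured step bears on this change, so there is no basis for expecting a shift in this assay beyond the scatter in either direction. Compound 3 is estimated to return 50000 nM, with a range from 15000 nM to 150000 nM, and most likely to be reported as a limit once more. The expected step of a number no higher from compound 1 to compound 3 (the limit leaves the size open) is thus essentially none.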

Compound 3, concentration for 50% growth inhibition: > 50000 nM
Compound 3 was reported as a limit (the forecaster's own chance of this, stated with the estimate: 80%); the middle value sits exactly at the limit.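

In this assay compound 3 gives > 50000 nM, again a limit of the assay, so the step from compound 1 to it cannot be read: the limit of > 50000 nM in this assay, at which 3 of the 3 values shown sit.

The compounds shown leave open how strongly any of them inhibits growth, and whether either change alters it.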